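A few compounds are considered here, and "the series" means these few. Any claim that something is new, unique, unknown or untested is made for them only; others in the source may bear on it.

Working notes on the series built on the shared core of compound 1 `C=CC(=O)N1C(=O)CC(c2ccc(C)cc2)Sc2ccccc21`, where the group on one aromatic carbon is varied. In a functional assay on MOLT-4 cells (Homo sapiens) for cytotoxicity, read by CCK-8 assay, with a stated time of 24 h (a higher number here means a weaker inhibitor, a lower number a stronger inhibitor), compound 1 gives 87600 nM. Compound 2 `C=CC(=O)N1C(=O)CC(c2ccc(C(=O)OC)cc2)Sc2ccccc21` gives 79600 nM in this assay, and compound 3 `C=CC(=O)N1C(=O)CC(c2ccc(Br)cc2)Sc2ccccc21` gives 106000 nM. Compound 2 holds the lowest of the three numbers, but both gaps to it are within the scatter: a 1.1-fold lower number from compound 1 to compound 2 (0.04 log units; within the scatter) and a 1.3-fold higher number from compound 2 to compound 3 (0.12 log units; within the scatter). The remaining pair, a 1.2-fold higher number from compound 1 to compound 3 (0.08 log units; within the scatter), is within the scatter as well, so none of the three can be set apart from the others.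

Compound 4 `C=CC(=O)N1C(=O)CC(c2ccc(C#N)cc2)Sc2ccccc21` has not yet been measured in this assay. Relative to compound 2 the change is cyano in place of methoxycarbonyl on an aromatic carbon. The measured steps that bear on it are the two exchanges at this same aromatic carbon, a 1.1-fold lower number from compound 1 to compound 2 (0.04 log units; within the scatter) and a 1.3-fold higher number from compound 2 to compound 3 (0.12 log units; within the scatter), both within the scatter, so three different groups at that carbon return numbers that cannot be told apart. Compound 4 is therefore expected to show no step beyond the scatter, a 1.1-fold higher number from compound 2 to compound 4 (0.03 log units; within the scatter). Compound 4 is estimated at 85000 nM, with a range from 45000 nM to 160000 nM.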

Compound 4, half-maximal inhibitory concentration: 88700 nM
For compound 4 the middle estimate is 1.0-fold (0.02 log units) below the measured one; the range from low to high includes it.
By their numbers in this assay, from the lowest: compounds 2, 1, 4 and 3 (each within the scatter of the next).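

In this assay, cyano adds a fourth group on this aromatic carbon, para to a large group, and each of its three new steps stays within the scatter: cyano for methoxycarbonyl (a 1.1-fold higher number from compound 2 to compound 4 (0.05 log units; within the scatter)), cyano for bromo (a 1.2-fold lower number from compound 3 to compound 4 (0.08 log units; within the scatter)) and cyano for methyl (a 1.0-fold higher number from compound 1 to compound 4 (0.01 log units; within the scatter)). The exchange for methoxycarbonyl goes from 4 heavy atoms to 2, from a double bond outside aromatic rings to a triple bond, and from 2 hydrogen-bond acceptors to 1, yet the step does not leave the scatter, so none of these counted differences separates the two compounds here. Nothing measured on these compounds offers an explanation for why the four groups cannot be told apart.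

Going by these compounds, whether an amine or a carboxylic acid on this same carbon would give a step beyond the scatter remains open. Also open, on these data alone, is whether a change elsewhere on the shared core, such as replacing the acryloyl group, would move the number when the aromatic carbon barely registers an exchange.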